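A few compounds are considered here, and "the series" means these few. Any claim that something is new, unique, unknown or untested is made for them only; others in the source may bear on it.

Compound 1 `O=C(NCC1(c2nc(-c3ccccc3)cs2)CCOCC1)c1ccc(-n2cncn2)cc1`: 191000 nM
Compound 2 `O=C(NCC1(c2nc(-c3ccccc3)cs2)CCOCC1)c1ccc(Nc2nc3ccccc3s2)cc1`: 4000 nM

In a physicochemical assay for solubility, read by chemiluminescence, in phosphate buffer, measured as kinetic solubility, at pH 7.4 (on this read-out lower numbers stand for lower solubility and higher numbers for higher solubility), compound 2 has the lower of the two numbers, at 4000 nM. Compound 3 `O=C(NCC1(c2nc(-c3ccccc3)cs2)CCOCC1)c1ccc(Nc2nncs2)cc1` differs from it in one group: 1,3,4-thiadiazol-2-yl in place of 1,3-benzothiazol-2-yl on a nitrogen on an aromatic ring. In words, this puts 1,3,4-thiadiazol-2-yl in place of 1,3-benzothiazol-2-yl on a nitrogen on an aromatic ring. Among the compounds with values here, only one measured step bears on this, and it is large: a 48-fold lower number from compound 1 to compound 2 (1.68 log units; beyond the scatter). That step introduced the group now being replaced, so a partial return towards the higher number is expected, though one step is a thin guide. The expected change is a 6.3-fold higher number from compound 2 to compound 3 (0.80 log units; beyond the scatter). For compound 3 the estimated value is 25000 nM, with an expected range of 7000 nM to 90000 nM.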

Compound 3, solubility: 29000 nM
The estimate for compound 3 lay 1.2-fold (0.06 log units) below the measured number, within the range that was stated.
By their numbers in this assay, from the lowest: compound 2; then compound 3; then compound 1.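

In this assay, keeping the nitrogen on the aromatic ring and trading 1,3-benzothiazol-2-yl for the smaller 1,3,4-thiadiazol-2-yl gives a 7.3-fold higher number from compound 2 to compound 3 (0.86 log units; beyond the scatter) with the rest of the molecule unchanged. The number therefore depends on the group carried by that nitrogen, not on the nitrogen link alone. Even so, (1,3,4-thiadiazol-2-yl)amino in place of 1H-1,2,4-triazol-1-yl gives a 6.6-fold lower number from compound 1 to compound 3 (0.82 log units; beyond the scatter) on the same aromatic carbon.

Where a pyridin-2-yl on that nitrogen, or a morpholine on that aromatic carbon, would fall remains open. Nothing shown gives a reason for these steps.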